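The compounds below may be only part of what the source reports. "The series", "measured", "known", "first", "only" and "open" are said of these compounds alone.

Compound 1 `CCO/N=C/Nc1cc(Cl)c([S+]([O-])CC)c(Cl)c1` gives 2.9 in a physicochemical assay for lipophilicity, measured as octanol-water partition; a lower number here means a more polar compound, a higher number a more lipophilic compound. Compound 2 `CCO/N=C/Nc1cc(Cl)c(S(=O)(=O)CC)c(Cl)c1` gives 2.8. Compound 3 `CCO/N=C/Nc1cc(Cl)c(OC)c(Cl)c1` gives 3.7.

Among these three numbers compound 1 stands second highest. Its nearest neighbour is compound 2, with a number 0.10 log units lower from compound 1 to compound 2 (within the scatter). The furthest is compound 3, with a number 0.80 log units higher from compound 1 to compound 3 (beyond the scatter).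

Compound 4 `CC#CCOc1c(Cl)cc(N/C=N/OCC)cc1Cl` differs from compound 1 at the same aromatic carbon that varies across the measured set: a group of 5 heavy atoms (4 carbon, 1 oxygen; no ring) in place of a group of 4 heavy atoms (2 carbon, 1 oxygen, 1 sulfur; no ring), on an aromatic carbon. The measured steps that bear on this change are those in which a sulfur-containing group gave way to methoxy: a number 0.80 log units higher from compound 1 to compound 3 (beyond the scatter) and a number 0.90 log units higher from compound 2 to compound 3 (beyond the scatter), both modest rises beyond the scatter. Within the data shown here, the (but-2-yn-1-yl)oxy group is a longer chain than methoxy, so the rise in this assay from compound 1 is expected to exceed the rise seen for compound 3 at 3.7; no measured pair shows how much the added chain contributes, so the range is wide. The estimated step is a number 1.60 log units higher from compound 1 to compound 4 (beyond the scatter). Compound 4 is therefore expected to reach about 4.5, within a range from 4 to 5.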

Compound 4, partition coefficient: 4
Estimate against measurement, compound 4: 0.50 log units above; the range from low to high includes it.
By their numbers in this assay, from the lowest: compounds 2 and 1 (each within the scatter of the next); then compounds 3 and 4 (each within the scatter of the next).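

In this assay the (but-2-yn-1-yl)oxy group on this aromatic carbon, ortho to two chloro groups, gives a number 1.10 log units higher from compound 1 to compound 4 (beyond the scatter) and a number 1.20 log units higher from compound 2 to compound 4 (beyond the scatter), so the large separation from the two sulfur-containing groups extends beyond methoxy. Placing prop-1-yn-1-yl on the methoxy carbon gives only a number 0.30 log units higher from compound 3 to compound 4 (within the scatter), which means the longer chain on the oxygen adds nothing this assay can resolve, contrary to what compound 3 alone could indicate. No available evidence accounts for these steps.

The compounds shown leave open whether a saturated butoxy group would match compound 4, so the share of the triple bond in its number remains unknown. They also leave open where an amine or a carboxylic acid on this aromatic carbon would stand in this assay.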